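Hexyloxy for fluoro on the sulfonamide aryl ring

The compounds below may be only part of what the source reports. "The series", "measured", "known", "first", "only" and "open" are said of these compounds alone.

Compound 2 `O=C1NCCN1c1ccc(S(=O)(=O)Nc2ccc(F)cc2)cc1` gives 230 nM in a functional assay on M21 cells (Homo sapiens) for antiproliferative activity, read by sulforhodamine B assay, with a stated time of 48 h (on this read-out lower numbers stand for stronger inhibition and higher numbers for weaker inhibition), and so has the highest of the three numbers measured. Compound 1 `CCc1ccccc1NS(=O)(=O)c1ccc(N2CCNC2=O)cc1` gives 180 nM and compound 3 `Cc1cccc(NS(=O)(=O)c2ccc(N3CCNC3=O)cc2)c1C` gives 110 nM. Compound 4 `CCCCCCOc1ccc(NS(=O)(=O)c2ccc(N3CCNC3=O)cc2)cc1` differs from compound 2 in one place: hexyloxy in place of fluoro on an aromatic carbon. Both steps that change this same aryl group bear on it: a 1.3-fold higher number from compound 1 to compound 2 (0.11 log units; within the scatter), and a 2.1-fold lower number from compound 2 to compound 3 (0.32 log units; beyond the scatter). For the measured compounds named here, these changes moved the number little, so a change to a hexyloxy chain, for which no measured step exists, is expected to give at most a modest step downward in this assay, a 1.5-fold lower number from compound 2 to compound 4 (0.19 log units; within the scatter). Compound 4 is therefore estimated at 150 nM, with a range from 60 nM to 400 nM.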

Compound 4, half-maximal inhibitory concentration: > 1000 nM
Compound 4 ended at the assay's limit; the forecaster's own chance of this, stated with the estimate: 5%; middle value at least 6.6-fold (0.82 log units) from the limit.
By their numbers in this assay, from the lowest: compounds 3, 1 and 2 (each within the scatter of the next, the first and the last beyond it). At a limit, above all of these: compound 4.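

In this assay compound 4 stands at a limit of the assay, not at a number: the limit of > 1000 nM in this assay, at which 1 of the 4 values shown sits.

Hexyloxy in place of fluoro on this aromatic carbon, para to a large group, gives an at least 4.3-fold higher number from compound 2 to compound 4 (0.63 log units; beyond the scatter). So this aryl group is not as indifferent to change as the earlier steps suggested, since this is the first step there that raises the number beyond the scatter.

The compounds shown leave open where between fluoro and hexyloxy the number turns upward, for instance with methoxy or butoxy. They also leave open whether a hexyl chain without its oxygen would behave the same way.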